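Butenolide series: ring stereocentre inversion from compound 3 to compound 4

The compounds below may be only part of what the source reports. "The series", "measured", "known", "first", "only" and "open" are said of these compounds alone.

Measured compounds and their numbers in a functional assay on HCT-15 cells (Homo sapiens) for cytotoxicity; a higher number here means that more compound is needed for the effect, a lower number that less compound is needed:
compound 1, `CC1=C(O)[C@@H](C/C(C)=C\CC[C@H](C)/C=C/C=C(\C)CCCc2ccoc2)OC1=O`: 6.5 ug/mL
compound 2, `CC1=C(O)[C@@H](C/C(C)=C\CC[C@H](C)/C=C/C=C(\C)CCCC2=CCN(CCC(C)C)C2=O)OC1=O`: 3.8 ug/mL
compound 3, `CCC(C)CN1CC=C(CCC/C(C)=C/C=C/[C@@H](C)CC/C=C(/C)C[C@@H]2OC(=O)C(C)=C2O)C1=O`: 5.3 ug/mL

All three share the same core and the same long chain; they differ only in the group at the chain end. Compound 3 stands second highest of the three numbers in this assay. Its nearest neighbour is compound 1, its furthest is compound 2, and both gaps lie within the scatter, so no order among the three can be read from the values shown.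

Among the measured compounds shown here, the one measured step, a 1.7-fold lower number from compound 1 to compound 2 (0.23 log units; within the scatter), exchanges a group of 5 heavy atoms for a group of 11 heavy atoms on a saturated chain carbon, three bonds along the chain from a double-bonded chain carbon, and stays within the scatter.

Compound 4, `CCC(C)CN1CC=C(CCC/C(C)=C/C=C/[C@@H](C)CC/C=C(/C)C[C@H]2OC(=O)C(C)=C2O)C1=O`, is compared with compound 3: the two compounds have the same atoms and bonds; at least one stereo element is drawn with a configuration in one of them and without one in the other: 1 of 6 stereo elements differ; a stereocentre at a saturated ring carbon is drawn S in compound 3 and R in compound 4. For the measured compounds named here, no measured step changes a stereocentre, so nothing among the measured pairs bears directly on this change; the only known step, which alters a group rather than a configuration, was itself within the scatter. The expected step is therefore no change at the digits printed from compound 3 to compound 4 (within the scatter), with no direction beyond the scatter. For compound 4 the estimate is 5.3 ug/mL, expected between 2.5 ug/mL and 11 ug/mL.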

Compound 4, concentration for half-maximal effect: 22.3 ug/mL
For compound 4 the middle estimate is 4.2-fold (0.62 log units) below the measured one; measured number above the stated range.
By their numbers in this assay, from the lowest: compounds 2, 3 and 1 (each within the scatter of the next); then compound 4.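

In this assay, among the compounds shown here, the ring stereocentre is the first position where a change moves the number beyond the scatter: a 4.2-fold higher number from compound 3 to compound 4 (0.62 log units; beyond the scatter), with S in the lower-numbered compound and R in the higher. The chain-end group also matters for compound 4, since sec-butyl in place of isobutyl on the saturated chain carbon bound to the amide-type nitrogen gives a 5.9-fold higher number from compound 2 to compound 4 (0.77 log units; beyond the scatter). The group of 11 heavy atoms in place of the group of 5 heavy atoms gives a 3.4-fold higher number from compound 1 to compound 4 (0.54 log units; beyond the scatter), whereas the same kind of exchange gave only a 1.7-fold lower number from compound 1 to compound 2 (0.23 log units; within the scatter), so compound 4 stands apart from the other three compounds, and an exchange that looked silent depends on the exact end group.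

The stereochemical reading carries one limit: the fact that one of compounds 3 and 4 is drawn with a defined configuration and the other without, at the place where they differ. From the compounds shown here alone, whether the ring stereocentre has the same size of step with another substituent on the ring nitrogen, such as a primary amine or a carboxylic acid at the end of a longer chain, remains open.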